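Alkynyl nucleosides on murine leukaemia cells: deleting the hydroxy

The compounds below may be only part of what the source reports. "The series", "measured", "known", "first", "only" and "open" are said of these compounds alone.

Compound 1 `C#Cc1cn(C2O[C@H](CO)[C@@H](O)[C@@H]2O)c(=O)[nH]c1=O` carries hydrogen on the triple-bonded carbon; in a functional assay on L1210 cells (Mus musculus) (on this read-out lower numbers stand for stronger inhibition and higher numbers for weaker inhibition), compound 1 gives 45 ug/mL. Compound 3 `CCC#Cc1cn(C2O[C@H](CO)[C@@H](O)[C@@H]2O)c(=O)[nH]c1=O` carries ethyl in that place on the same core. In this assay compound 3 returns only a limit, > 1000 ug/mL. Among the measured compounds shown here, the step of an at least 22-fold higher number from compound 1 to compound 3 (1.34 log units; beyond the scatter) is the only measured change in the set, and it is large. Compound 2 `O=c1[nH]c(=O)n([C@H]2C[C@H](O)[C@@H](CO)O2)cc1C#CCCO` pairs a 4-hydroxybut-1-yn-1-yl chain with a different core and differs from compound 3 in two places. In this assay compound 2 likewise returns only a limit, > 1000 ug/mL, so it sits at the weak end of the numbers shown and cannot be ranked further. Compound 4 `CCC#Cc1cn([C@H]2C[C@H](O)[C@@H](CO)O2)c(=O)[nH]c1=O` differs from compound 2 by hydrogen in place of hydroxy on a saturated chain carbon, two bonds along the chain from a triple-bonded carbon. For the measured compounds named here, no measured step tracks this change; the one step measured alters the triple-bonded carbon itself. Given (the limit of > 1000 ug/mL in this assay, at which 2 of the 3 values shown sit), compound 4 is expected to stay at the limit, with a step of a number no higher from compound 2 to compound 4 (the limit leaves the size open) not beyond the scatter. Compound 4 is estimated at 1000 ug/mL, within 300 ug/mL to 3000 ug/mL.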

Compound 4, concentration for 50% inhibition: > 1000 ug/mL
Compound 4: only a limit was reported; the forecaster's own chance of this, stated with the estimate: 75%; the middle value lies on the limit itself.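

Compound 2 and compound 4 both return only limits in this assay, so no step can be read between them: the limit of > 1000 ug/mL in this assay, at which 3 of the 4 values shown sit.

The compounds shown leave open whether hydroxy or hydrogen at this place on the chain makes any difference to inhibition on this core.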